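Phenyl in Place of Methyl: Two Pairs, One Change

The source may report more compounds than this note shows. Statements on the series, on what has been measured and on what is new or still open speak of the compounds shown alone.

Compound 1 `COc1ccc(/C=N/Nc2nc(C)c[se]2)cc1` and compound 2 `COc1ccc(/C=N/Nc2nc(-c3ccccc3)c[se]2)cc1` share one core, and compound 2 carries phenyl in place of methyl on an aromatic carbon. In a functional assay on HepG2 cells (Homo sapiens) for cytotoxicity, read by XTT assay, with a stated time of 72 h (a higher number here means a weaker inhibitor, a lower number a stronger inhibitor), compound 1 gives 83200 nM, and compound 2 gives 50500 nM. That step is a 1.6-fold lower number from compound 1 to compound 2 (0.22 log units; within the scatter).

Compound 3 `Cc1c[se]c(NNC(=O)c2ccc(Cl)cc2)n1` is built on a different core; how its core differs from that of compound 1 is not broken down here. In this assay compound 3 reaches only a limit of the assay, > 79400 nM, which is the limit of > 79400 nM in this assay, at which 1 of the 3 values shown sits.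

Compound 4 `O=C(NNc1nc(-c2ccccc2)c[se]1)c1ccc(Cl)cc1` is compound 3 with phenyl in place of methyl on an aromatic carbon, the same change as between compound 1 and compound 2, at the same place. Because the earlier step was a 1.6-fold lower number from compound 1 to compound 2 (0.22 log units; within the scatter), the expected step here is an at least 1.3-fold lower number from compound 3 to compound 4 (0.12 log units; that floor lies within the scatter), a small one. Compound 4 is expected to give about 60000 nM in this assay, likely between 25000 nM and 150000 nM.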

Compound 4, half-maximal inhibitory concentration: 62900 nM
The estimate for compound 4 lay 1.0-fold (0.02 log units) below the measured number; the range from low to high includes it.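

On the core of compound 3, phenyl in place of methyl gives an at least 1.2-fold lower number from compound 3 to compound 4 (0.10 log units; that floor lies within the scatter) in this assay. The value of compound 3, > 79400 nM, is a limit of the assay and not a number. The two steps do not conflict, so nothing here speaks against the change carrying from one core to the other, but they show neither that it carries over by the same amount nor that it moves the number beyond the scatter on the core of compound 3: the same change on two cores in this assay, a 1.6-fold lower number (0.22 log units; within the scatter) from compound 1 to compound 2 and an at least 1.2-fold lower number (0.10 log units; that floor lies within the scatter) from compound 3 to compound 4; the limit leaves it open whether they differ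

Only methyl and phenyl appear at this place on the ring. Going by these compounds, how an amine or a carboxylic acid there would read in this assay remains open, on either core.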